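Succinimide Piperazine Amides in the Maximal Electroshock Model

A few compounds are considered here, and "the series" means these few. Any claim that something is new, unique, unknown or untested is made for them only; others in the source may bear on it.

Three compounds sharing one core were tested in a functional assay on the whole organism (strain Swiss) with Mus musculus as the target, in the maximal electroshock model, with a stated time of 0.5 h, at a dose of 300 mg/kg by the intraperitoneal route; on this read-out higher numbers stand for a stronger effect at the one dose given and lower numbers for a weaker effect. Compound 1 `CCC(C(=O)N1CCN(c2cccc(C(F)(F)F)c2)CC1)N1C(=O)CCC1=O` carries a trifluoromethyl group on the aromatic ring and an ethyl-bearing chain; in this assay compound 1 gives 50%. Compound 2 `CCC(C(=O)N1CCN(c2cccc(C)c2)CC1)N1C(=O)CCC1=O` differs from compound 1 by methyl in place of trifluoromethyl on an aromatic carbon, and in this assay compound 2 gives 100%. Compound 3 `CC(C(=O)N1CCN(c2cccc(C(F)(F)F)c2)CC1)N1C(=O)CCC1=O` differs from compound 1 by hydrogen in place of methyl on a saturated chain carbon, two bonds along the chain from an amide-type nitrogen in a ring and a carbonyl carbon, and in this assay compound 3 gives 100%. Both changes moved the read-out in the same direction: a number 50 percentage points higher from compound 1 to compound 2 (beyond the scatter), and a number 50 percentage points higher from compound 1 to compound 3 (beyond the scatter). Compound 2 and compound 3 stand level at the digits printed, and both sit at the top of the scale that this read-out can report.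

Compound 4 `Cc1cccc(N2CCN(C(=O)C(C)N3C(=O)CCC3=O)CC2)c1` has not yet been tested. It differs from compound 3 by methyl in place of trifluoromethyl on an aromatic carbon, which is the same change as that from compound 1 to compound 2. When that change was made on the core of compound 1, the step was a number 50 percentage points higher from compound 1 to compound 2 (beyond the scatter). For compound 4, however, the starting point is compound 3, which already gives 100% and so leaves no room above it. The step from compound 3 to compound 4 is therefore expected to be no change at the digits printed from compound 3 to compound 4 (within the scatter), because compound 3 gives 100% and the same change earned a number 50 percentage points higher from compound 1 to compound 2 (beyond the scatter) elsewhere. Compound 4 is estimated to give 100% in this assay, with a range from 90% to 100%.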

Compound 4, a percentage reported as activity, at one dose (the size of the read-out at that dose, not a potency): 50%
Estimate against measurement, compound 4: 50 percentage points above, and the stated range ends above it.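

In this assay, methyl in place of trifluoromethyl did not keep its direction on moving to the second core, giving a number 50 percentage points lower from compound 3 to compound 4 (beyond the scatter), and its earlier rise became a fall: the same change on two cores in this assay, a number 50 percentage points higher (beyond the scatter) from compound 1 to compound 2 and a number 50 percentage points lower (beyond the scatter) from compound 3 to compound 4, 100 percentage points apart, beyond the scatter of two such steps

The change on the chain, hydrogen in place of methyl, reversed in the same way, giving a number 50 percentage points lower from compound 2 to compound 4 (beyond the scatter), against its earlier rise on the core of compound 1: the same change on two cores in this assay, a number 50 percentage points higher (beyond the scatter) from compound 1 to compound 3 and a number 50 percentage points lower (beyond the scatter) from compound 2 to compound 4, 100 percentage points apart, beyond the scatter of two such steps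

Across these four compounds, then, neither change has an effect that can be read apart from the other group present, so the result of either one cannot be carried from one core to the other; the two reversals are also two views of a single set of four compounds, not independent findings, and they do not show why the direction turns, nor how far it would hold at any other dose, since the read-out reports the size of the effect at one dose and not a potency.

The compounds shown leave open what a chlorine atom or a methoxy group on the same aromatic carbon would give on either core. They also leave open whether a propyl chain in place of the ethyl-bearing chain would follow compound 1 or compound 2.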